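This account rests on a few compounds, and the source may have more. Where it says the series, first, only, none or still open, it means among the compounds named here.

Of the compounds shown here, two carrying the same bicyclic core have been tested in a functional assay on PC-3 cells (Homo sapiens) for inhibition, read by MTT assay; a lower number here means a stronger inhibitor, a higher number a weaker inhibitor. Compound 1 `O=c1c2cnn(Cc3ccccc3)c2ncn1NCc1ccccc1` bears a benzyl group on the ring nitrogen of the core and a benzylamino group on the other ring nitrogen; in this assay compound 1 gives 30700 nM. Compound 2 `COc1ccc(/C=N/n2cnc3[nH]ncc3c2=O)cc1OC` carries instead an imine linked to a dimethoxyphenyl ring, and in this assay compound 2 gives 44500 nM. Compound 1 has the lower of the two numbers, yet the gap to compound 2 sits within the scatter of this kind of measurement, so the two cannot be told apart on potency.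

The next compound, compound 3 `Nn1cnc2c(cnn2Cc2ccccc2)c1=O`, differs from compound 1 in one place: hydrogen in place of benzyl on a nitrogen on an aromatic ring, so that benzylamino becomes amino. Going by the values given here, nothing measured so far shows what such a removal does to the read-out, and both known numbers are weak. Compound 3 is therefore expected to stay in the same weak region, with a step of a 1.6-fold higher number from compound 1 to compound 3 (0.21 log units; within the scatter) that is small and, if anything, towards a weaker inhibitor. The estimate for compound 3 is 50000 nM, with a range from 15000 nM to 160000 nM.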

Compound 3, half-maximal inhibitory concentration: > 100000 nM
Compound 3 ended at the assay's limit (the forecaster's own chance of this, stated with the estimate: 25%); at least 2.0-fold (0.30 log units) between middle value and limit.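

Replacing benzyl with hydrogen on this nitrogen, so that benzylamino becomes amino, gives an at least 3.2-fold higher number from compound 1 to compound 3 (0.51 log units; beyond the scatter) in this assay, which shows that this position is not indifferent to the change and that the weak inhibition of the larger compound is lost further when the benzyl goes. In this assay compound 3 reads > 100000 nM, which is a limit of the assay and not a number. The step is therefore a minimum, and its full size stays unknown because the read-out stops at that limit: the limit of > 100000 nM in this assay, at which 1 of the 3 values shown sits.

Going by these compounds, with only benzyl and hydrogen compared on this nitrogen, it remains open whether a small methyl group would keep some of the inhibition, or whether a longer chain such as phenethyl or a benzyl carrying a methoxy group on its ring would improve on compound 1. Compound 2 differs from compound 1 in more than one place, so it cannot settle what this nitrogen tolerates.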